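Swapping one chain stereocentre at the assay's ceiling

The source may hold more compounds than are shown below. What is called first, only, known or untested is meant among the compounds shown, and "the series" means these compounds.

Among the compounds with values here, compound 1 `COC[C@H](C(C)C)C(c1ccc(O)c(OC)c1)c1ccc(O)c(OC)c1` is the only member of this small set with a numerical reading: in a functional assay on HeLa cells (Homo sapiens) for cytotoxicity, read by WST assay, with a stated time of 48 h (a higher number here means a weaker inhibitor, a lower number a stronger inhibitor), compound 1 gives 76000 nM. Compound 2 `COc1ccc(C(c2ccc(OC)c(OC)c2)[C@@H](C)[C@H](C)CO)cc1OC` reaches only a limit of the assay, and in this assay compound 2 gives > 100000 nM. Compound 3 `COc1ccc(C(c2ccc(OC)c(OC)c2)[C@@H](C)[C@@H](C)CO)cc1OC` likewise reaches only a limit, and in this assay compound 3 gives > 100000 nM. So compound 3 stands at the ceiling of what the assay can report, with one other compound at the same ceiling, and the step that the two limits leave unreadable from compound 2 to compound 3 cannot be read, owing to the limit of > 100000 nM in this assay, at which 2 of the 3 values shown sit. Compound 4 `COc1ccc(C(c2ccc(OC)c(OC)c2)[C@H](C)[C@@H](C)CO)cc1OC` is not yet measured. It differs from compound 3 in a single respect: the two compounds have the same atoms and bonds and differ only in configuration as drawn: 1 of 2 stereo elements differ; a stereocentre at a saturated chain carbon is drawn R in compound 3 and S in compound 4. Within the data shown here, the one measured step that bears on such a change is a step that the two limits leave unreadable from compound 2 to compound 3, and since it is unreadable no size can be drawn from it. The expected step that the limit leaves unreadable from compound 3 to compound 4 is therefore taken as none beyond the scatter, most likely ending again at the limit. Compound 4 is estimated at 150000 nM, within a range from 60000 nM to 400000 nM.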

Compound 4, half-maximal inhibitory concentration: 67000 nM
Estimate against measurement, compound 4: 2.2-fold (0.35 log units) above; low and high end bracket the measured number.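

Among these same-atom compounds, compound 4 alone gives a number rather than a limit, so inverting this chain stereocentre can now be given a floor: this assay shows an at least 1.4-fold lower number from compound 3 to compound 4 (0.17 log units; that floor lies within the scatter). Inverting both stereocentres, which gives the mirror image, shows an at least 1.4-fold lower number from compound 2 to compound 4 (0.17 log units; that floor lies within the scatter), while the step between compounds 2 and 3 still cannot be read. Both floors lie within the scatter, so any real gap here cannot yet be told from repeat-measurement noise, though any such gap would belong to configuration alone: the fact that compounds 3 and 4 differ only in the configuration as drawn

The compounds shown leave open how far compounds 2 and 3 really lie from compound 4, since each of those two is known only as a limit. They also leave open whether this stereocentre would matter with an amine or a carboxylic acid on the chain.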